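Branched Amine Side Chain on a Shared Triazolopyrimidine-Type Core

The source may report more compounds than this note shows. Statements on the series, on what has been measured and on what is new or still open speak of the compounds shown alone.

Measured so far in an in vitro assay on 293-EBNA cells for binding affinity to corticotropin-releasing factor receptor 1 (Homo sapiens); on this read-out lower numbers stand for stronger inhibition and higher numbers for weaker inhibition:
compound 1 `CCCCN(CC)c1nc(C)nc2c1nnn2-c1ccc(C(C)C)cc1Br` gives 7.5 nM
compound 2 `CCCCNc1nc(C)nc2c1nnn2-c1ccc(C(C)C)cc1Br` gives 69.6 nM

Compound 2 stands at the higher of the two numbers, the weaker of the pair. Among the compounds with values here, the only measured step, a 9.3-fold higher number from compound 1 to compound 2 (0.97 log units; beyond the scatter), lies beyond the scatter and runs from the dialkylated nitrogen to the monoalkylated one.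

Compound 3 `CCCCC(CCCC)Nc1nc(C)nc2c1nnn2-c1ccc(C(C)C)cc1Br` differs from compound 2 by 1-butylpentyl in place of butyl on a nitrogen on an aromatic ring. This change sits on the same nitrogen as the measured step, but in the opposite sense: where the measured step took carbons away from that nitrogen and the number rose, this step adds carbons through the branched chain. The expected direction is therefore downward, beyond the scatter, and the size is estimated near that of the measured step, as a 7.0-fold lower number from compound 2 to compound 3 (0.84 log units; beyond the scatter). Compound 3 is expected to give about 10 nM, in the range 3 nM to 40 nM.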

Compound 3, inhibition constant: 4.5 nM
Compound 3: middle estimate off by 2.2-fold (0.35 log units), on the high side; low and high end bracket the measured number.
By their numbers in this assay, from the lowest: compounds 3 and 1 (each within the scatter of the next); then compound 2.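

In this assay, 1-butylpentyl in place of butyl on a nitrogen on an aromatic ring gives a 15-fold lower number from compound 2 to compound 3 (1.19 log units; beyond the scatter), so this nitrogen can carry a hydrogen and still reach the level of compound 1 when its one chain is branched. A second group on the nitrogen is therefore not required for that level: the comparison of the two side chains reads a 1.7-fold lower number from compound 1 to compound 3 (0.22 log units; within the scatter), which leaves them level in this assay. Nothing measured here explains why a branched chain on this nitrogen matches the dialkylated one.

The compounds shown leave open how much of the branched chain is needed, as a smaller 1-ethylpropyl group or a cyclopentyl ring would show. They also leave open whether a methoxyethyl chain, with its ether oxygen, would be accepted on this nitrogen.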